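Amide-nitrogen aryl variation across a shared core

The compounds below may be only part of what the source reports. "The series", "measured", "known", "first", "only" and "open" are said of these compounds alone.

Measured in an assay on isolated protein for inhibition of histone deacetylase 4 (Homo sapiens), with a stated time of 1 h; on this read-out higher numbers stand for weaker inhibition and lower numbers for stronger inhibition:
Compound 1 `O=C(COc1ccc2cc(/C=C3/SC(=O)NC3=O)ccc2c1)Nc1cccc(F)n1` gives 840 nM.
Compound 2 `O=C(COc1ccc2cc(/C=C3/SC(=O)NC3=O)ccc2c1)Nc1ccc(F)cc1F` gives 3900 nM.

Within the data shown here, compound 2 holds the highest of the two numbers measured so far; its nearest neighbour is compound 1, and the single measured step, a 4.6-fold higher number from compound 1 to compound 2 (0.67 log units; beyond the scatter), is modest but beyond the scatter. Compound 3 `O=C(COc1ccc2cc(/C=C3/SC(=O)NC3=O)ccc2c1)Nc1ccc(F)cc1` differs from compound 2 by hydrogen in place of fluoro on an aromatic carbon. Among the measured compounds shown here, no measured step isolates this change: the one step available swaps the whole 6-fluoropyridin-2-yl group for 2,4-difluorophenyl, so the effect of the fluoro ortho to the large group cannot be separated from the other differences in that exchange. The expectation for compound 3 in this assay is therefore a small step with no direction supported beyond the scatter, and the estimate stays close to compound 2 with a wide range. For compound 3 the estimate is 3000 nM, within a range from 1200 nM to 7500 nM. This estimate means a 1.3-fold lower number from compound 2 to compound 3 (0.11 log units; within the scatter), a step expected to remain within the scatter.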

Compound 3, half-maximal inhibitory concentration: 1600 nM
For compound 3 the middle estimate is 1.9-fold (0.27 log units) above the measured one; low and high end bracket the measured number.
By their numbers in this assay, from the lowest: compounds 1 and 3 (each within the scatter of the next); then compound 2.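

The fluoro ortho to a large group now has a read of its own: in this assay, going from 2,4-difluorophenyl to 4-fluorophenyl gives a 2.4-fold lower number from compound 2 to compound 3 (0.39 log units; beyond the scatter), a modest change from a single-atom exchange of fluoro for hydrogen, and one in the direction of stronger inhibition. The earlier exchange of the whole aryl group looks different in this light, since a 1.9-fold higher number from compound 1 to compound 3 (0.28 log units; within the scatter) places 4-fluorophenyl and 6-fluoropyridin-2-yl on the amide-type nitrogen with no separation between them, so the gap seen for compound 2 goes with the added fluoro on the phenyl ring and not with phenyl as such. Nothing alongside these numbers gives a reason for the fluoro's effect on this read-out.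

The compounds shown leave open whether the penalty is specific to fluoro at this carbon, as a chloro, methyl, methoxy or amino group there would test. They also leave open what the remaining fluoro contributes, which the unsubstituted phenyl group on the same amide-type nitrogen would show.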